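The source may report more compounds than this note shows. Statements on the series, on what has been measured and on what is new or still open speak of the compounds shown alone.

In an ADME assay on LLC-PK1 cells (Sus scrofa) for permeability, with a stated time of 3 h, tested at 1 uM (on this read-out higher numbers stand for higher permeability and lower numbers for lower permeability), compound 1 `O=C(O)CNC(=O)c1c(O)c2c(n(Cc3ccc(Cl)cc3)c1=O)CCOC2` gives 3.6 10^-6 cm/s. Compound 2 `O=C(O)CNC(=O)c1c(O)c2c(n(Cc3ccc(F)cc3F)c1=O)COC2` gives < 2.2 10^-6 cm/s, which is a limit of the assay and not a number. For the measured compounds named here, it is the one compound of the two that stands at the limit of < 2.2 10^-6 cm/s in this assay, at which 1 of the 2 values shown sits, so its true position is not known. Compound 3 `O=C(O)CNC(=O)c1c(O)c2c(n(Cc3cnc(C(F)(F)F)s3)c1=O)COC2` carries 2-(trifluoromethyl)-1,3-thiazol-5-yl in place of 2,4-difluorophenyl on a saturated chain carbon bound to an aromatic nitrogen. Going by the values given here, no measured pair isolates a change of this kind, so no step beyond the scatter is expected in this assay. The estimated change, a step that the limit leaves unreadable from compound 2 to compound 3, is expected to be small and of no firm direction. For compound 3 the expected value is 2.1 10^-6 cm/s, with an estimated range from 1.2 10^-6 cm/s to 4 10^-6 cm/s.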

Compound 3, apparent permeability: < 1.5 10^-6 cm/s
Compound 3 was reported as a limit (the forecaster's own chance of this, stated with the estimate: 55%); middle value at least 1.4-fold (0.14 log units) from the limit.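

In this assay compound 3 gives < 1.5 10^-6 cm/s, a limit of the assay and not a number. For the compounds shown here, compound 2 also stands at a limit, so no step between compound 2 and compound 3 can be read. The compounds shown leave open where the true values of both lie, and whether 2-(trifluoromethyl)-1,3-thiazol-5-yl in place of 2,4-difluorophenyl shifts the read-out at all.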